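The source may hold more compounds than are shown below. What is called first, only, known or untested is meant among the compounds shown, and "the series" means these compounds.

Going by the values given here, compound 1 `COc1ccc(/C=C/C(=O)N/N=c2/[nH]ncc3ccccc23)cc1` is the only compound here with a number: in an ADME assay on THP-1 cells (Homo sapiens) for cytotoxicity, read by MTT assay, with a stated time of 72 h (a lower number here means a stronger inhibitor, a higher number a weaker inhibitor), compound 1 gives 437000 nM. Compound 2 `O=C(/C=C/c1ccc(OC(F)(F)F)cc1)NNC(=O)c1ccncc1` has no result in this assay, "not determined" (no result reported), and compound 3 `COc1ccc(/C=C/C(=O)N[C@@H]2CONC2=O)cc1` likewise gives "not determined" (no result reported), so compound 1 stands alone as the one measured point. Compound 4 `CC(C)=CCC/C(C)=C/COc1ccc(/C=C/C(=O)N/N=c2/[nH]ncc3ccccc23)cc1` is built from compound 1 by one change: 2,6-dimethylhepta-1,5-dien-1-yl in place of hydrogen on a saturated chain carbon bound to an oxygen on an aromatic ring. Among the compounds with values here, no step between two measured compounds is available to calibrate this change. The expected step is a 4.4-fold lower number from compound 1 to compound 4 (0.64 log units; beyond the scatter), toward a lower number, beyond the usual scatter. For compound 4 the estimated value in this assay is 100000 nM, with a plausible range from 30000 nM to 400000 nM.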

Compound 4, half-maximal inhibitory concentration: 56000 nM
Compound 4: the middle estimate sits 1.8-fold (0.25 log units) above what was measured; low and high end bracket the measured number.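

Replacing the methoxy of compound 1 with (3,7-dimethylocta-2,6-dien-1-yl)oxy gives a 7.8-fold lower number from compound 1 to compound 4 (0.89 log units; beyond the scatter) in this assay. Going by these compounds alone, this is the first sign that the number responds to a change on this saturated chain carbon bound to an oxygen on an aromatic ring, and that a chain this long can sit there while cytotoxicity remains measurable. Still open, on these data alone, is how a shorter chain such as ethyl, or an amine or carboxylic acid on the chain, would compare. The reason for the shift also stays open, with no measurement here bearing on it.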